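This account rests on a few compounds, and the source may have more. Where it says the series, first, only, none or still open, it means among the compounds named here.

Of the compounds shown here, three built on one shared core have been measured in a functional assay on HCT-15 cells (Homo sapiens) for inhibition; a lower number here means a stronger inhibitor, a higher number a weaker inhibitor. Compound 1 `Oc1cccc(-c2cc(-c3ccccc3F)cc(-c3ccccc3O)n2)c1` gives 8470 nM. Compound 2 `Oc1cccc(-c2cc(-c3ccccc3F)cc(-c3cccc(O)c3)n2)c1` gives 5300 nM. Compound 3 `Oc1cccc(-c2cc(-c3ccc(OC(F)(F)F)cc3)cc(-c3ccccc3O)n2)c1` gives 9410 nM. The values of compound 3 and compound 1 lie within the scatter of each other, as do those of compound 3 and compound 2, so nothing separates these three by strength.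

From compound 1 to compound 2 the change is 3-hydroxyphenyl in place of 2-hydroxyphenyl on an aromatic carbon, and the step it made was a 1.6-fold lower number from compound 1 to compound 2 (0.20 log units; within the scatter).

Compound 4 `Oc1cccc(-c2cc(-c3ccc(OC(F)(F)F)cc3)cc(-c3cccc(O)c3)n2)c1` has not yet been measured. It differs from compound 3 by 3-hydroxyphenyl in place of 2-hydroxyphenyl on an aromatic carbon. How the core of compound 3 differs from that of compound 1 is not broken down here. The surroundings of the change are also not identical: in compound 1 the carbon carrying the group is meta to a 2-fluorophenyl group, while in compound 3 it is meta to a large group, so the two changes are the same kind of change, not the same one.

Because the earlier step of a 1.6-fold lower number from compound 1 to compound 2 (0.20 log units; within the scatter) was within the scatter, the step from compound 3 to compound 4 is expected to be of a similar modest size, estimated as a 1.6-fold lower number from compound 3 to compound 4 (0.20 log units; within the scatter). On that basis compound 4 is expected to give about 6000 nM, with a likely range from 3000 nM to 12000 nM.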

Compound 4, half-maximal inhibitory concentration: > 50000 nM
Compound 4 ended at the assay's limit (the forecaster's own chance of this, stated with the estimate: 5%); middle value at least 8.3-fold (0.92 log units) away from the limit.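

In this assay compound 4 gives > 50000 nM, which is a limit of the assay and not a number. Putting 3-hydroxyphenyl in place of 2-hydroxyphenyl here gave an at least 5.3-fold higher number from compound 3 to compound 4 (0.72 log units; beyond the scatter), so on this core the change clearly weakens inhibition, and it does not repeat what the same change did on the other core: the same change on two cores in this assay, a 1.6-fold lower number (0.20 log units; within the scatter) from compound 1 to compound 2 and an at least 5.3-fold higher number (0.72 log units; beyond the scatter) from compound 3 to compound 4, at least 8.4-fold (0.92 log units) apart, beyond the scatter of two such steps. This shows that, in this small set, the result of this change on one core cannot be taken over to another, but it rests on a single pair of compounds per core, it gives only a lower bound for the new step since compound 4 sits at a limit, and it does not show which difference between the two cores is responsible.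

The compounds shown leave open how the same change would turn out on cores carrying other groups in the place where the 2-fluorophenyl group of compound 1 stands, and so whether the result on compound 4 is a rare case or the more common one. They also leave open what an amine or a carboxylic acid in place of the hydroxyl on this ring would do to inhibition on either core.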